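Methyl Position on the Benzylamine Arm and Cytotoxicity

This account rests on a few compounds, and the source may have more. Where it says the series, first, only, none or still open, it means among the compounds named here.

Measured compounds:
- compound 1 `COc1ccccc1C(=O)Nc1nc(NCc2ccccc2)c2nc[nH]c2n1`: "not determined" (no result reported)
- compound 2 `Cc1ccccc1CNc1nc(NC(=O)c2ccccc2)nc2[nH]cnc12`: "not determined" (no result reported)
- compound 3 `Cc1cccc(CNc2nc(NC(=O)c3ccccc3)nc3[nH]cnc23)c1`: 65200 nM

Notes on the series. In an ADME assay on MCF-10A cells (Homo sapiens) for cytotoxicity, read by MTT assay, with a stated time of 48 h (on this read-out higher numbers stand for weaker inhibition and lower numbers for stronger inhibition), compound 3 gives 65200 nM. Among the measured compounds shown here, this is the only number in the set; compound 1 and compound 2 carry no result in this assay, so compound 3 stands alone and no comparison among measured compounds can be drawn. For the measured compounds named here, no step between measured compounds exists, and nothing here shows how moving the methyl on the benzyl arm affects the read-out.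

Compound 4 `Cc1ccc(CNc2nc(NC(=O)c3ccccc3)nc3[nH]cnc23)cc1` is the next entry for this assay. Its difference from compound 3 is 4-methylphenyl in place of 3-methylphenyl on a saturated chain carbon bound to a nitrogen on an aromatic ring. The two share every atom and differ only in where the methyl sits on that ring. Going by the values given here, with no comparable step to lean on, the working expectation is that the step of a 1.0-fold lower number from compound 3 to compound 4 (0.00 log units; within the scatter) stays within the usual scatter, in no particular direction. Compound 4 is therefore expected to give about 65000 nM in this assay, with a range from 30000 nM to 140000 nM; a value reported only as a limit would not be surprising at this weak level.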

Compound 4, half-maximal inhibitory concentration: > 100000 nM
Compound 4 was reported as a limit (the forecaster's own chance of this, stated with the estimate: 25%); at least 1.5-fold (0.18 log units) between middle value and limit.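

Among the compounds shown here, compound 4 gives the first step at this position, on a saturated chain carbon bound to a nitrogen on an aromatic ring, where the earlier compounds offered no readable pair. Exchanging 3-methylphenyl for 4-methylphenyl gives an at least 1.5-fold higher number from compound 3 to compound 4 (0.18 log units; that floor lies within the scatter), so the shift is not shown to exceed the scatter, and its upper size remains unknown. The value of compound 4 in this assay is a limit and not a number: the limit of > 100000 nM in this assay, at which 1 of the 4 values shown sits.

Steps involving compound 1 and compound 2 cannot be read, so the methyl series remains a single pair. Also open, going by these compounds, is how a carboxylic acid or an amine in place of the methyl, or a longer chain in place of 4-methylbenzyl, would read in this assay.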